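Thiophen-3-yl for 1H-pyrrol-3-yl on a shared core

The source may report more compounds than this note shows. Statements on the series, on what has been measured and on what is new or still open speak of the compounds shown alone.

Measured so far in a functional assay on HL-60 cells (Homo sapiens) for inhibition; on this read-out lower numbers stand for stronger inhibition and higher numbers for weaker inhibition:
compound 1 `OC[C@H]1OC(n2cnc3c(-c4cc[nH]c4)ncnc32)[C@H](O)[C@@H]1O` — 3200 nM
compound 2 `Cc1ccsc1-c1ncnc2c1ncn2C1O[C@H](CO)[C@@H](O)[C@H]1O` — 4500 nM
compound 3 `OC[C@H]1OC(n2cnc3c(-c4nccs4)ncnc32)[C@H](O)[C@@H]1O` — 6300 nM

Compound 1 gives the lowest of these three numbers, but the steps of a 1.4-fold higher number from compound 1 to compound 2 (0.15 log units; within the scatter) and a 2.0-fold higher number from compound 1 to compound 3 (0.29 log units; within the scatter) both lie within the scatter, so the three compounds cannot be placed in any order in this assay.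

Compound 4 `OC[C@H]1OC(n2cnc3c(-c4ccsc4)ncnc32)[C@H](O)[C@@H]1O` differs from compound 1 by thiophen-3-yl in place of 1H-pyrrol-3-yl on an aromatic carbon. The two steps that bear on this exchange are those just named, each replacing the 1H-pyrrol-3-yl by another five-membered aromatic ring, and each stayed within the scatter. No step beyond the scatter is therefore expected here. Compound 4 is estimated at 3800 nM, with a range from 1500 nM to 9500 nM. That estimate corresponds to an expected step of a 1.2-fold higher number from compound 1 to compound 4 (0.07 log units; within the scatter).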

Compound 4, half-maximal inhibitory concentration: 3800 nM
Beside the measured number, compound 4's estimate shows no gap at the digits printed; measured number inside the range.
By their numbers in this assay, from the lowest: compounds 1, 4, 2 and 3 (each within the scatter of the next).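

In this assay, thiophen-3-yl carries no hydrogen-bond donor where 1H-pyrrol-3-yl carries one, yet the exchange gives only a 1.2-fold higher number from compound 1 to compound 4 (0.07 log units; within the scatter). The other two steps, a 1.7-fold lower number from compound 3 to compound 4 (0.22 log units; within the scatter) and a 1.2-fold lower number from compound 2 to compound 4 (0.07 log units; within the scatter), also stay within the scatter, so the four five-membered aromatic rings on this aromatic carbon cannot be told apart. From the compounds shown here alone, whether an amine, a carboxylic acid or a phenyl ring here would give a step beyond the scatter stays open. Nothing available accounts for the closeness of these four numbers.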